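From 2,4-difluorophenyl to 2-chlorophenyl: one step in the series

A few compounds are considered here, and "the series" means these few. Any claim that something is new, unique, unknown or untested is made for them only; others in the source may bear on it.

In an in vivo ADME assay on the whole organism for pharmacokinetics, with Canis familiaris (Canis lupus familiaris) as the target (a lower number here means that a smaller share of the oral dose reaches the circulation, a higher number that a larger share of the oral dose reaches the circulation), compound 1 `CC(C)(C)N1CCC(c2cc(-c3ccc(F)cc3Cl)c3ccc(=O)n(-c4c(Cl)cccc4Cl)c3c2)CC1` gives 83% and compound 2 `CC(C)(C)N1CCC(c2cc3c(ccc(=O)n3-c3c(Cl)cccc3Cl)c(-c3ccc(F)cc3F)n2)CC1` gives 99.3% as its reading. Compound 2 holds the higher of the two numbers, and the gap down to compound 1 lies beyond the scatter. These two compounds differ in more than one place, so the gap cannot be tied to any single change.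

Compound 3 `CC(C)(C)N1CCC(c2cc3c(ccc(=O)n3-c3c(Cl)cccc3Cl)c(-c3ccccc3Cl)n2)CC1` has no reading yet. It keeps the core of compound 2 and carries one change: 2-chlorophenyl in place of 2,4-difluorophenyl on an aromatic carbon with 2-chlorophenyl in place of 2,4-difluorophenyl on an aromatic carbon, next to the ring nitrogen. For the measured compounds named here, no measured pair isolates this swap, so the expected size of the step is poorly anchored. With compound 2 at 99.3% there is almost no room upward, so a fall is expected rather than a rise, of moderate size and possibly beyond the scatter. The working figure is an estimated fall (a number 23.3 percentage points lower from compound 2 to compound 3 (beyond the scatter)). In this assay the estimate for compound 3 is 76% (expected range 50% to 98%).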

Compound 3, oral bioavailability: 9.35%
For compound 3 the middle estimate is 66.7 percentage points above the measured one, and the stated range ends above it.
By their numbers in this assay, from the lowest: compound 3; then compound 1; then compound 2.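

In this assay, the aryl group on the aromatic carbon next to the ring nitrogen proves to be a sensitive place: with the rest of the structure held fixed, 2-chlorophenyl in place of 2,4-difluorophenyl gives a number 90 percentage points lower from compound 2 to compound 3 (beyond the scatter). For the compounds shown here, this is the first step that isolates a single place, and the change is only one phenyl group for another, with hydrogen-bond donors, hydrogen-bond acceptors and net charge the same in the two groups. The data shown offer nothing that bears on why the step is so large.

The swap takes out two fluorine atoms and brings in one chlorine atom, so the compounds shown cannot say which part of the change carries the fall. From the compounds shown here alone, a 2-fluorophenyl or an unsubstituted phenyl group on the same carbon would separate these parts, and whether a step of this size also appears on the core of compound 1 remains open.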